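Trifluoromethyl for Fluoro on the Aryl Ring

The compounds below may be only part of what the source reports. "The series", "measured", "known", "first", "only" and "open" are said of these compounds alone.

Of the compounds shown here, three sharing one core have been tested in a functional assay on MCF7 cells (Homo sapiens) for cytotoxicity, read by MTT assay, with a stated time of 72 h; a lower number here means a stronger inhibitor, a higher number a weaker inhibitor. Compound 1 `O=C(Nc1ccc(Oc2ccnc3[nH]ccc23)cc1)c1nccc(-c2cccc(Cl)c2)n1` gives 10200 nM, compound 2 `COc1ccc(-c2ccnc(C(=O)Nc3ccc(Oc4ccnc5[nH]ccc45)cc3)n2)cc1` gives 12400 nM, and compound 3 `O=C(Nc1ccc(Oc2ccnc3[nH]ccc23)cc1)c1cc(-c2ccc(F)cc2)ncn1` gives 15900 nM, the highest of the three numbers, though each lies within the scatter of the others. Compound 4 `O=C(Nc1ccc(Oc2ccnc3[nH]ccc23)cc1)c1cc(-c2ccc(C(F)(F)F)cc2)ncn1` differs from compound 3 by trifluoromethyl in place of fluoro on an aromatic carbon. For the measured compounds named here, only one step among the measured compounds exists, a 1.2-fold higher number from compound 1 to compound 2 (0.08 log units; within the scatter), and it swaps a different pair of groups, so no measured step bears directly on this change. Going by the values given here, the single step seen is within the scatter, and the three values spread little; the change from compound 3 to compound 4 is therefore expected to be a 1.1-fold lower number from compound 3 to compound 4 (0.06 log units; within the scatter). Compound 4 is estimated at 14000 nM, with a likely range from 5000 nM to 40000 nM.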

Compound 4, half-maximal inhibitory concentration: 6240 nM
Compound 4: the middle estimate sits 2.2-fold (0.35 log units) above what was measured, and the stated range covers the measured number.
By their numbers in this assay, from the lowest: compounds 4, 1, 2 and 3 (each within the scatter of the next, the first and the last beyond it).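

In this assay, this carbon of the aryl ring responds to a change of group: trifluoromethyl in place of fluoro gives a 2.5-fold lower number from compound 3 to compound 4 (0.41 log units; beyond the scatter), a modest step but the first here beyond the scatter. For the compounds shown here, the only earlier step, a 1.2-fold higher number from compound 1 to compound 2 (0.08 log units; within the scatter), swapped a different pair of groups and stayed within the scatter. Nothing measured here accounts for the new step.

As far as these compounds go, whether a nitrile or an amine on the same carbon would shift the number further remains open. So does whether trifluoromethyl would act alike on the core of compound 1.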